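Aryl replacement on the core of compound 3

The source may hold more compounds than are shown below. What is called first, only, known or untested is meant among the compounds shown, and "the series" means these compounds.

The series shares the core of compound 1, `Nc1nc(-c2ccc(Cl)cc2)c(CC(=O)O)s1`, which in an in vitro assay on HEK385-7 cells for displacement of a labelled ligand from prostaglandin D2 receptor 2 (Homo sapiens) (on this read-out lower numbers stand for stronger inhibition and higher numbers for weaker inhibition), gives a limit of > 100000 nM rather than a number, as noted in the limit of > 100000 nM in this assay, at which 1 of the 3 values shown sits. Compound 2, `CCC(c1ccccc1)c1nc(-c2ccc(Cl)cc2)c(CC(=O)O)s1`, gives 190 nM in this assay. Compound 3, `O=C(O)Cc1sc(C(c2ccc(F)cc2)c2ccc(F)cc2)nc1-c1cc(F)cc(F)c1`, gives 35 nM in this assay and stands as the lowest of the two numbers shown, with compound 2 the nearest at a higher number, a gap beyond the scatter.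

Compound 4, `O=C(O)Cc1sc(C(c2ccc(F)cc2)c2ccc(F)cc2)nc1-c1ccnc(N2CCCC2)c1`, is not yet measured in this assay. It differs from compound 3 in one place: 2-(pyrrolidin-1-yl)pyridin-4-yl in place of 3,5-difluorophenyl on an aromatic carbon. Going by the values given here, no measured pair tests this kind of change, so the size of the step is open. The carboxymethyl group and the bis(4-fluorophenyl)methyl group of compound 3 are kept, and the step is expected to be small, in either direction or within the scatter; the estimate leans to a slightly higher number, as the step of a 1.7-fold higher number from compound 3 to compound 4 (0.23 log units; within the scatter) expresses. Compound 4 is expected to give about 60 nM in this assay, within a range from 15 nM to 300 nM.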

Compound 4, half-maximal inhibitory concentration: 230 nM
The estimate for compound 4 lay 3.8-fold (0.58 log units) below the measured number, within the range that was stated.
By their numbers in this assay, from the lowest: compound 3; then compounds 2 and 4 (each within the scatter of the next). At a limit, above all of these: compound 1.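

Going by these compounds alone, at the aromatic carbon next to the ring nitrogen, the first single-place change gives a 6.6-fold higher number from compound 3 to compound 4 (0.82 log units; beyond the scatter) in this assay, so this position is sensitive to replacing 3,5-difluorophenyl with 2-(pyrrolidin-1-yl)pyridin-4-yl. The change does not abolish the read-out, as compound 4 still gives a measured 230 nM and the larger group, with its two hydrogen-bond acceptors, remains compatible with a numerical value in this assay. Nothing measured in the series accounts for the size of this step.

This single step does not separate the contribution of the pyridin-4-yl ring from that of the pyrrolidin-1-yl group. An unsubstituted pyridin-4-yl would make that split, and a dimethylamino or morpholin-4-yl group in place of the pyrrolidin-1-yl group would show how far this step depends on that ring.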